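This account rests on a few compounds, and the source may have more. Where it says the series, first, only, none or still open, it means among the compounds named here.

In an ADME assay on MDCK cells (Canis lupus familiaris) for cytotoxicity, read by MTT assay, with a stated time of 24 h (on this read-out lower numbers stand for higher toxicity in this test and higher numbers for lower toxicity in this test), compound 1 `N#CCCN(Cc1cccs1)S(=O)(=O)c1ccc(Cl)cc1` gives > 195000 nM as its reading, which is a limit of the assay and not a number. Compound 2 `COc1ccc(S(=O)(=O)N(CCC#N)Cc2cccs2)cc1` gives > 198000 nM as its reading, again a limit and not a number. Among the compounds with values here, compound 2 therefore has no exact value to start from, and the only other reading beside it is also a limit.

Compound 3 `N#CCCN(Cc1cccs1)S(=O)(=O)c1ccc(C(F)(F)F)cc1` carries trifluoromethyl in place of methoxy on an aromatic carbon, para to a large group (trifluoromethyl in place of methoxy on an aromatic carbon). Within the data shown here, the one measured step that bears on this change is methoxy in place of chloro on an aromatic carbon (a step that the two limits leave unreadable from compound 1 to compound 2) and it offers no size to carry over. The expectation thus rests on the two limits alone, and no step beyond the usual scatter is expected in this assay in either direction. The estimated move (an at least 1.1-fold lower number from compound 2 to compound 3 (0.04 log units; that floor lies within the scatter)) stays within that scatter. For compound 3 the estimated concentration is 180000 nM with an expected range of 100000 nM to 260000 nM in this estimate, and the reading may well prove to be a limit again.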

Compound 3, half-maximal cytotoxic concentration: > 178000 nM
Compound 3: only a limit was reported (the forecaster's own chance of this, stated with the estimate: 85%); the middle value lies beyond the limit too.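

In this assay compound 3 gives > 178000 nM, which is a limit of the assay and not a number. Within the data shown here, since compound 1, compound 2 and compound 3 all have only limits, no step among them can be read. The compounds shown leave open the actual half-maximal cytotoxic concentration of each, and whether exchanging chloro, methoxy and trifluoromethyl changes it at all.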